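A few compounds are considered here, and "the series" means these few. Any claim that something is new, unique, unknown or untested is made for them only; others in the source may bear on it.

Of the compounds shown here, three that share a core have been tested in an assay on cells for inhibition of S-adenosylmethionine decarboxylase proenzyme (Homo sapiens), read by mass spectrometry, at pH 7.2; on this read-out higher numbers stand for weaker inhibition and lower numbers for stronger inhibition. Compound 1 `Cc1cc(Nc2cc(Cl)cc(Cl)c2)ncn1` gives in this assay no number but a limit of the assay, > 180000 nM. Compound 2 `Cc1cc(Nc2cc(Cl)cc(Cl)c2)nc(N(C)C)n1` likewise gives in this assay only a limit, > 180000 nM. The step from compound 1 to compound 2, a step that the two limits leave unreadable from compound 1 to compound 2, cannot be sized because both values sit at the limit of > 180000 nM in this assay, at which 2 of the 3 values shown sit. Compound 3 `Cc1cc(Nc2cc(Cl)c(C)c(Cl)c2)nc(N)n1` gives in this assay only a limit as well, > 63000 nM. That limit is the limit of > 63000 nM in this assay, at which 1 of the 3 values shown sits, so compound 3 stands where no number is known, much as the other two.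

Compound 4 `Cc1cc(Nc2cc(Cl)c(N3CCCCC3)c(Cl)c2)nc(N)n1` differs from compound 3 by piperidin-1-yl in place of methyl on an aromatic carbon. Going by the values given here, no measured step resembles this change, and the single measured step, from compound 1 to compound 2, is unreadable. Among the compounds with values here, with every value so far a limit, compound 4 is expected to remain a weak inhibitor in this assay, with the step from compound 3 to compound 4 estimated as a step that the limit leaves unreadable from compound 3 to compound 4. Compound 4 is therefore expected to give about 100000 nM in this assay, in a range from 20000 nM to 500000 nM, quite possibly again only as a limit.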

Compound 4, half-maximal inhibitory concentration: > 180000 nM
Compound 4: no number, only a limit (the forecaster's own chance of this, stated with the estimate: 70%); middle value at least 1.8-fold (0.25 log units) from the limit.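

In this assay, compound 3 and compound 4 both give only a limit of the assay and no number, so the step between them cannot be read. The compounds shown leave open whether any change to the shared core yields a measurable inhibitory concentration.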